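From methylamino to chloro on a clearance read-out

The source may report more compounds than this note shows. Statements on the series, on what has been measured and on what is new or still open speak of the compounds shown alone.

Measured so far:
compound 1 (`CNc1nc(NC)nc(NC2(C#N)CCCCC2)n1`) gives 210 mL/min/kg in clearance
compound 2 (`CCCC(C#N)(CC)Nc1nc(NC)nc(-n2cncn2)n1`) gives 29 mL/min/kg in clearance

In an ADME assay on microsomes from liver (Rattus norvegicus) for metabolic stability (on this read-out lower numbers stand for slow clearance and higher numbers for fast clearance), compound 1 holds the higher of the two numbers. At 210 mL/min/kg compound 1 lies beyond the scatter above compound 2, which stands at 29 mL/min/kg on the same read-out.

The step followed here leads to compound 3 (`CNc1nc(Cl)nc(NC2(C#N)CCCCC2)n1`), which keeps the core of compound 1 and changes one group: chloro in place of methylamino on an aromatic carbon. The change lies between two ring nitrogen atoms, opposite the ring nitrogen.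

Among the compounds with values here, no measured pair shows a change of this kind, so the data give no direct size for it. Within the data shown here, the only guide is that compound 1, at 210 mL/min/kg in this assay, sits at the top of the known numbers, which leaves more room below it than above. A small fall is therefore expected, and the expected step of a 1.8-fold lower number from compound 1 to compound 3 (0.24 log units; within the scatter) may stay within the scatter. For compound 3 the estimated clearance is 120 mL/min/kg within an expected range of 40 mL/min/kg to 300 mL/min/kg in this estimate.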

Compound 3, clearance: 867 mL/min/kg
For compound 3 the middle estimate is 7.2-fold (0.86 log units) below the measured one; measured number outside the range, above it.
By their numbers in this assay, from the lowest: compound 2; then compound 1; then compound 3.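

In this assay, replacing methylamino with chloro on this aromatic carbon, between two ring nitrogen atoms, gives a 4.1-fold higher number from compound 1 to compound 3 (0.62 log units; beyond the scatter). This single change therefore moves clearance upward by more than the usual scatter, which shows that the group at this position matters for this read-out on the core of compound 1. The methylamino group that leaves carries a hydrogen-bond donor and a hydrogen-bond acceptor while chloro carries neither, but nothing available connects either difference, or any other feature of the change, to the rise.

The compounds shown leave open whether the higher number goes with the arrival of chloro or the departure of methylamino, a question that a methoxy group, a fluoro group or an unsubstituted amino group at the same aromatic carbon could help to settle. From the compounds shown here alone, it is also open whether the step keeps its direction and size when a morpholine group takes the place of the remaining methylamino group.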